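Unmeasured analogue of an inactive diaryl compound

The source may report more compounds than this note shows. Statements on the series, on what has been measured and on what is new or still open speak of the compounds shown alone.

The shared core of compound 1 `C=CCn1c(=O)/c(=C\c2ccccc2Cl)[nH]c(=O)/c1=C\c1ccccc1OC` carries two aryl groups on double-bonded chain carbons, and in a functional assay on U-937 cells (Homo sapiens) for cytotoxicity, read by CCK-8 assay, with a stated time of 72 h (on this read-out higher numbers stand for weaker inhibition and lower numbers for stronger inhibition), compound 1 gives 700 nM. Within the data shown here, compound 2 `C=CCn1c(=O)/c(=C\c2ccc(C)cc2)[nH]c(=O)/c1=C\c1ccccc1OC` keeps the same core and differs only in one of the aryl groups; in this assay compound 2 is reported as "not active" (no number reported), so no single number places it against compound 1, and it can be said only that compound 1 has a measured value where compound 2 has none.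

Compound 3 `C=CCn1c(=O)/c(=C\c2cc(F)ccc2C)[nH]c(=O)/c1=C\c1ccccc1OC` has not yet been measured. It differs from compound 2 by 5-fluoro-2-methylphenyl in place of 4-methylphenyl on a double-bonded chain carbon bound to an aromatic carbon. Among the measured compounds shown here, no step between measured compounds covers such a change, so the size and direction of the step from compound 2 to compound 3 in this assay are unknown; the change involves both a new fluorine and a moved methyl, and anything from no change beyond the scatter to a return toward the range of compound 1 is possible.

On that basis, compound 3 is estimated to give about 3000 nM in this assay, with an expected range from 600 nM to 15000 nM, and a real chance that only inactivity is reported.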

Compound 3, half-maximal inhibitory concentration: 1000 nM
For compound 3 the middle estimate is 3.0-fold (0.48 log units) above the measured one, within the range that was stated.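

In this assay compound 3 gives 1000 nM where compound 2 has only a report of inactivity, so at this double-bonded chain carbon bound to an aromatic carbon, 5-fluoro-2-methylphenyl in place of 4-methylphenyl separates a measured value from no number, though the size of that step cannot be read. The exchange of 2-chlorophenyl for 5-fluoro-2-methylphenyl at the same place gives a 1.4-fold higher number from compound 1 to compound 3 (0.15 log units; within the scatter), so these two groups are not told apart in this read-out, and among the three compounds only 4-methylphenyl goes with no number. No measurement offered here explains why these groups differ in this way.

The compounds shown do not separate the contribution of the fluorine from that of the moved methyl, as plain 2-methylphenyl is not among them. They also leave open whether a phenyl group carrying a carboxylic acid or a dimethylamino group at this place would give a number at all, and how far the other aryl group can be changed.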